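Carbamate selenocyanates and a diselenide: cytotoxicity notes

The source may hold more compounds than are shown below. What is called first, only, known or untested is meant among the compounds shown, and "the series" means these compounds.

Measured compounds, with their values in a functional assay on HT-29 cells (Homo sapiens) for cytotoxicity, read by MTT assay, with a stated time of 72 h; a higher number here means that more compound is tolerated, a lower number that less compound is tolerated:
compound 1 `CC(C)COC(=O)Nc1ccc([Se]C#N)cc1`: 63700 nM
compound 2 `C=CCOC(=O)Nc1ccc([Se]C#N)cc1`: 72800 nM
compound 3 `CCCCOC(=O)Nc1ccc([Se][Se]c2ccc(NC(=O)OCCCC)cc2)cc1`: 82400 nM

All three numbers lie within the scatter of one another, so no order among them can be read. Compound 2 stands between the other two: the nearest is compound 3, the furthest compound 1, and both gaps are within the scatter. Among the measured compounds shown here, the one step that can be followed in detail, a 1.1-fold higher number from compound 1 to compound 2 (0.06 log units; within the scatter), is a change of the alkyl part of the carbamate and moved nothing beyond the scatter.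

Compound 4 `CCOC(=O)Nc1ccc([Se]C#N)cc1` carries the same carbamate selenocyanate core as compound 2 and differs from it in a single place: methyl in place of vinyl on a saturated chain carbon bound to an oxygen next to a carbonyl group. This is a change of the same kind as the step from compound 1 to compound 2, an exchange of one small alkyl chain for another on a saturated chain carbon bound to an oxygen next to a carbonyl group. Since that measured step stayed within the scatter, no step beyond the scatter is expected here in either direction in this assay.

Compound 4 is therefore estimated at 70000 nM in this assay, with a range of 35000 nM to 140000 nM. The step this estimate implies, a 1.0-fold lower number from compound 2 to compound 4 (0.02 log units; within the scatter), is expected to stay within the scatter.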

Compound 4, concentration lethal to 50% of the cells: 66600 nM
Estimate against measurement, compound 4: 1.1-fold (0.02 log units) above; the measured number falls inside the stated range.
By their numbers in this assay, from the lowest: compounds 1, 4, 2 and 3 (each within the scatter of the next).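

The double bond of the vinyl group is not needed to hold the number in this range: in this assay the exchange of vinyl for methyl on a saturated chain carbon bound to an oxygen next to a carbonyl group gives a 1.1-fold lower number from compound 2 to compound 4 (0.04 log units; within the scatter) and so adds a saturated, unbranched case to the earlier step, which involved no loss of that double bond on the saturated side. The second new comparison, with methyl in place of isopropyl at the same place, gives a 1.0-fold higher number from compound 1 to compound 4 (0.02 log units; within the scatter) and shows that the shorter group also cannot be told apart from isopropyl, so that isopropyl, vinyl and methyl at this place now form a set of three selenocyanates with no readable order. Nothing measured here offers an explanation for this flat result.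

As far as these compounds go, whether an amine, a carboxylic acid or a longer chain at this place would bring a step beyond the scatter remains open. Also open, from the compounds shown here alone, is how the selenocyanate and the diselenide compare when the carbamate chain is held the same.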